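This account rests on a few compounds, and the source may have more. Where it says the series, first, only, none or still open, it means among the compounds named here.

Of the compounds shown here, three with a shared core have been measured so far. Compound 1 `Cc1ncccc1-c1cnc(NCc2c(F)ccc3c2CCO3)c2nn(CC#N)c(=O)n12`, compound 2 `CN(c1ncco1)c1cnc(NCc2c(F)ccc3c2CCO3)n2cnnc12` and compound 3 `Cc1ncc(-c2cnc(NCc3c(F)ccc4c3CCO4)c3cn[nH]c(=O)c23)n1C` were each run in a physicochemical assay for lipophilicity, using the shake flask method, in phosphate buffer, measured as octanol-water partition, with a stated time of 30 min, at pH 7.4; a lower number here means a more polar compound, a higher number a more lipophilic compound. Compound 1 gives 2.2, compound 2 gives 2.1 and compound 3 gives 1.9. Compound 2 thus stands second highest of the three numbers, nearest to compound 1 and furthest from compound 3, yet both gaps lie within the usual scatter, so no order among the three can be claimed. Compound 4 `O=C1CCCN1c1cnc(NCc2c(F)ccc3c2CCO3)n2cnnc12` is not yet measured. It differs from compound 2 in one place: 2-oxopyrrolidin-1-yl in place of methyl(1,3-oxazol-2-yl)amino on an aromatic carbon. Among the compounds with values here, no measured pair shows a change of this kind, so the expectation rests on compound 2 alone. A small downward step is expected, possibly just beyond the scatter: a number 0.40 log units lower from compound 2 to compound 4 (beyond the scatter). Compound 4 is therefore estimated at 1.7, between 1.2 and 2.2.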

Compound 4, distribution coefficient: 1.3
Beside the measured number, compound 4's estimate is 0.40 log units above it, and the stated range covers the measured number.
By their numbers in this assay, from the lowest: compound 4; then compounds 3, 2 and 1 (each within the scatter of the next).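

Replacing methyl(1,3-oxazol-2-yl)amino with 2-oxopyrrolidin-1-yl on this aromatic carbon gives, in this assay, a number 0.80 log units lower from compound 2 to compound 4 (beyond the scatter). Within the data shown here, this is the first difference in the set that clears the scatter, so the number does respond to the group at this position. Nothing shown explains why the number responds this way.

On these data alone, whether the ring of 2-oxopyrrolidin-1-yl matters stays open, since an open-chain acetamide or a dimethylamino group on this carbon could land anywhere. As far as these compounds go, whether the same change gives a similar step on the other cores also remains unknown.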